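Cytotoxicity notes: amide nitrogen variants, compound 3 to compound 4

The source may hold more compounds than are shown below. What is called first, only, known or untested is meant among the compounds shown, and "the series" means these compounds.

Compound 1 `Cc1cccc(C)c1NC(=O)CSc1snnc1-c1ccc(Br)cc1Br` gives >= 198000 nM in an ADME assay on MT4 cells (Homo sapiens) for cytotoxicity, read by MTT assay, with a stated time of 5 days (a higher number here means that more compound is tolerated, a lower number that less compound is tolerated), a limit of the assay.
Compound 2 `O=C(CSc1snnc1-c1ccc(Br)cc1Br)Nc1ccc(Cl)cc1` gives 23300 nM in this assay.
Compound 3 `O=C(CSc1snnc1-c1ccc(Br)cc1Br)Nc1ccccc1[N+](=O)[O-]` gives > 235000 nM in this assay, a limit of the assay.

Compound 3 thus stands at the upper edge of what this assay reports; of the three values shown, it and compound 1 both sit at limits (the limit of > 235000 nM in this assay, at which 1 of the 3 values shown sits, (the limit of >= 198000 nM in this assay, at which 1 of the 3 values shown sits)). For the measured compounds named here, the only readable step into compound 3 is an at least 10-fold higher number from compound 2 to compound 3 (1.00 log units; beyond the scatter), which is at least modest in the higher direction, while a step that the two limits leave unreadable from compound 1 to compound 3 cannot be sized. Compound 4 `O=C(CSc1snnc1-c1ccc(Br)cc1Br)Nc1ccccc1Cl` is not yet measured; its difference from compound 3 is chloro in place of nitro on an aromatic carbon.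

Going by the values given here, the steps that bear on this change are an at least 8.4-fold lower number from compound 1 to compound 2 (0.92 log units; beyond the scatter), where a chlorophenyl group lowered the number, and an at least 10-fold higher number from compound 2 to compound 3 (1.00 log units; beyond the scatter), where a nitrophenyl group raised it. Replacing nitro with chloro is expected to move the number back down, but compound 2 carries 4-chlorophenyl rather than 2-chlorophenyl, so the size is uncertain. For compound 4 an expected step of an at least 3.3-fold lower number from compound 3 to compound 4 (0.52 log units; beyond the scatter) is estimated, giving an expected value of 70000 nM with a range from 18000 nM to 235000 nM.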

Compound 4, half-maximal cytotoxic concentration: > 240000 nM
Compound 4: only a limit was reported (the forecaster's own chance of this, stated with the estimate: 35%); middle value at least 3.4-fold (0.53 log units) from the limit.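

Compound 4 reports only a limit of the assay: the limit of > 240000 nM in this assay, at which 1 of the 4 values shown sits. The chloro group therefore does not by itself bring the number down in this assay, since moving to 2-chlorophenyl from 4-chlorophenyl gives an at least 10-fold higher number from compound 2 to compound 4 (1.01 log units; beyond the scatter), and among these compounds the low reading goes with 4-chlorophenyl alone. Compounds 1, 3 and 4 all stand at limits, so the steps among them cannot be read, and nitro and chloro at this place cannot be ranked.

Going by these compounds, how far the tolerated concentrations of these three compounds lie past their limits remains open, as does any order among them. Also open, on these data alone, is whether an amine or a carboxylic acid in place of the chloro on this aromatic carbon would keep the reading at a limit.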